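A few compounds are considered here, and "the series" means these few. Any claim that something is new, unique, unknown or untested is made for them only; others in the source may bear on it.

Measured so far in an ADME assay on L6 cells (Rattus norvegicus) for cytotoxicity; on this read-out higher numbers stand for weaker inhibition and lower numbers for stronger inhibition:
- Compound 1 `O=C(CCN1CCCCC1)N1CCC2(N3CCCC3)CC(c3ccccc3)C1C(c1ccccc1)C2`: 108000 nM
- Compound 2 `c1ccc(C2CC3(N4CCCC4)CCN(CCN4CCCC4)C2C(c2ccccc2)C3)cc1`: 58200 nM
- Compound 3 `CN1CCN(CC(=O)N2CCC3(N4CCCC4)CC(c4ccccc4)C2C(c2ccccc2)C3)CC1`: 69100 nM

Compound 2 stands within the scatter of both other compounds, with a 1.9-fold lower number from compound 1 to compound 2 (0.27 log units; within the scatter) and a 1.2-fold higher number from compound 2 to compound 3 (0.07 log units; within the scatter). The remaining pair behaves alike, with a 1.6-fold lower number from compound 1 to compound 3 (0.19 log units; within the scatter).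

The unmeasured compound 4 `c1ccc(C2CC3(N4CCCCC4)CCN(CCN4CCCC4)C2C(c2ccccc2)C3)cc1` keeps the 2-(pyrrolidin-1-yl)ethyl group of compound 2 and changes on a saturated ring carbon: piperidin-1-yl in place of pyrrolidin-1-yl on a saturated ring carbon. Going by the values given here, no measured step touches that place, because all three compounds carry pyrrolidin-1-yl there, so the data hold no direct comparison. The three steps all concern the group on an amine nitrogen in a ring, and they bear on the new change only indirectly. Even so, the exchange behind a 1.9-fold lower number from compound 1 to compound 2 (0.27 log units; within the scatter) stayed within the scatter, so no shift beyond the scatter is expected in this assay. The expected change is a 1.2-fold lower number from compound 2 to compound 4 (0.07 log units; within the scatter). Compound 4 is estimated at 50000 nM, with an expected range from 20000 nM to 110000 nM.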

Compound 4, half-maximal inhibitory concentration: 156000 nM
Estimate against measurement, compound 4: 3.1-fold (0.49 log units) below, outside the stated range (above it).
By their numbers in this assay, from the lowest: compounds 2, 3, 1 and 4 (each within the scatter of the next, the first and the last beyond it).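

In this assay the change to piperidin-1-yl on the saturated ring carbon gives a 2.7-fold higher number from compound 2 to compound 4 (0.43 log units; beyond the scatter) and is the only step among the compounds shown to pass beyond the scatter. The three exchanges on the amine nitrogen in a ring all stayed within the scatter, so this result gives the first sign that the number responds to the group at this other place, here when a five-membered ring gives way to a six-membered one. Nothing available accounts for this shift.

As far as these compounds go, whether the number would keep rising or fall back with azepan-1-yl, morpholin-4-yl or an open-chain dimethylamino group at this carbon remains open. From the compounds shown here alone, it is also open whether piperidin-1-yl has the same effect when the amine nitrogen in a ring carries the acyl groups of compound 1 or compound 3.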